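This account rests on a few compounds, and the source may have more. Where it says the series, first, only, none or still open, it means among the compounds named here.

Three compounds share one core and differ only in the group on the sulfonyl-bearing ring: compound 1 `COc1ccc(Cc2nnc(NC(=O)/C(C#N)=C/c3ccccc3OS(=O)(=O)c3ccc(C)cc3)s2)cc1`, compound 2 `COc1ccc(Cc2nnc(NC(=O)/C(C#N)=C/c3ccccc3OS(=O)(=O)c3ccc(Cl)cc3)s2)cc1` and compound 3 `COc1ccc(Cc2nnc(NC(=O)/C(C#N)=C/c3ccccc3OS(=O)(=O)c3ccc(F)cc3)s2)cc1`. In a functional assay on RS4-11 cells (Homo sapiens) for inhibition, read by CCK-8 assay, with a stated time of 48 h, tested at 20 uM (a higher number here means more inhibition of growth at the concentration tested, a lower number less inhibition of growth), compound 1 gives 70%, compound 2 gives 79% and compound 3 gives 80%. On these numbers compound 2 sits between the other two, its gaps to each within the scatter. The three steps among them, a number 9 percentage points higher from compound 1 to compound 2 (within the scatter), a number 10 percentage points higher from compound 1 to compound 3 (within the scatter) and a number 1 percentage points higher from compound 2 to compound 3 (within the scatter), all stay within the scatter. Compound 4 `Cc1ccc(Cc2nnc(NC(=O)/C(C#N)=C/c3ccccc3OS(=O)(=O)c3ccc(Cl)cc3)s2)cc1` differs from compound 2 at a different place: methyl in place of methoxy on an aromatic carbon. Going by the values given here, no measured step touches that place, so nothing here points to a change beyond the scatter. Compound 4 is therefore expected to give 76% in this assay, between 58% and 90%. The expected step is a number 3 percentage points lower from compound 2 to compound 4 (within the scatter), within the scatter.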

Compound 4, percent growth inhibition at one concentration: 72%
For compound 4 the middle estimate is 4 percentage points above the measured one; low and high end bracket the measured number.
By their numbers in this assay, from the lowest: compounds 1, 4, 2 and 3 (each within the scatter of the next).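

Going by these compounds alone, the earlier compounds varied only the sulfonyl-bearing ring; compound 4 is the first change at the other end of the molecule, from 4-methoxybenzyl to 4-methylbenzyl. In this assay, the loss of the methoxy oxygen and its hydrogen-bond acceptor gives a number 7 percentage points lower from compound 2 to compound 4 (within the scatter), so this swap shows no change beyond the scatter at this position. Nothing available explains this result. As far as these compounds go, it remains open how an amine, a carboxylic acid or a longer chain on this aromatic carbon would read, and whether methyl in place of methoxy behaves alike with fluoro or methyl on the sulfonyl-bearing ring.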